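A few compounds are considered here, and "the series" means these few. Any claim that something is new, unique, unknown or untested is made for them only; others in the source may bear on it.

Of the compounds shown here, two sharing one core have been tested in a functional assay on MCF7 cells (Homo sapiens) for cytotoxicity, read by MTT assay, with a stated time of 72 h; a lower number here means a stronger inhibitor, a higher number a weaker inhibitor. Compound 1 `COc1ccc(-c2cc(C(=O)Nc3ccc(Oc4ccnc5[nH]ccc45)cc3)ncn2)cc1` gives 4450 nM in this assay. Compound 2 `O=C(Nc1ccc(Oc2ccnc3[nH]ccc23)c(F)c1)c1cc(-c2ccccc2)ncn1` gives 4640 nM in this assay, the higher of the two numbers, although its gap to compound 1 lies within the usual scatter, so the two cannot be told apart on these data. Compound 3 `COc1ccc(-c2cc(C(=O)Nc3ccc(Oc4ccnc5[nH]ccc45)c(F)c3)ncn2)cc1` has not yet been measured. It differs from compound 2 by methoxy in place of hydrogen on an aromatic carbon, placed on a six-membered aromatic ring of carbon only, para to a large group. Within the data shown here, no measured pair isolates this single change. Among the measured compounds shown here, the only guide is that compound 1 and compound 2, which differ in two places including this one, give numbers within the scatter of each other. The step of a 1.0-fold lower number from compound 2 to compound 3 (0.01 log units; within the scatter) is therefore expected to be small, none beyond the scatter. The estimated value for compound 3 in this assay is 4500 nM, with a range from 2000 nM to 10000 nM.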

Compound 3, half-maximal inhibitory concentration: 10400 nM
Compound 3: the middle estimate sits 2.3-fold (0.36 log units) below what was measured; the whole stated range lies below it.
By their numbers in this assay, from the lowest: compounds 1 and 2 (each within the scatter of the next); then compound 3.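

In this assay the change from phenyl to 4-methoxyphenyl now stands alone in one pair, and with the fluoro already present, methoxy in place of hydrogen gives a 2.2-fold higher number from compound 2 to compound 3 (0.35 log units; beyond the scatter) and so weakens the compound measurably. Fluoro in place of hydrogen, with the methoxy already present, gives a 2.3-fold higher number from compound 1 to compound 3 (0.37 log units; beyond the scatter), so each group costs activity when the other is there, and the compound carrying both has the highest number of the set. Nothing shown explains this rise.

Still open is whether the methoxy has the same effect without the fluoro, since the compounds shown offer no such pair. Also open, going by these compounds, is how an amine, a chlorine or a longer chain such as ethoxy would behave at the methoxy position.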